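The source may hold more compounds than are shown below. What is called first, only, known or untested is meant among the compounds shown, and "the series" means these compounds.

Compound 1 `COc1cc2c(/C=C3/C(=O)Nc4ccc(O)cc43)c(Cl)n(Cc3cc(OC)c(OC)c(OC)c3)c2cc1C` and compound 2 `O=C1/C(=C/c2c(Cl)[nH]c3ccccc23)c2ccccc2N1Cc1ccccc1` share a core in which a substituted indole is joined through an exocyclic double bond to an oxindole, and both were tested in a functional assay on cells (Cancer cell lines, Homo sapiens) for cytotoxicity, with a stated time of 48 h; on this read-out lower numbers stand for stronger inhibition of growth and higher numbers for weaker inhibition of growth. In this assay compound 1 gives 34700 nM, the lower of the two numbers reported, while compound 2 gives 69200 nM; the two values sit within the usual scatter of each other, so no order between them can be claimed.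

Compound 3 `COc1cc2c(/C=C3/C(=O)Nc4cccc(Cl)c43)c(Cl)n(Cc3cc(OC)c(OC)c(OC)c3)c2cc1C` has not yet been measured. It differs from compound 1 in one place: a group of 12 heavy atoms (9 carbon, 1 nitrogen, 1 oxygen, 1 chlorine; one five-membered non-aromatic ring with 1 hetero atom, one six-membered aromatic ring of carbon only) in place of a group of 12 heavy atoms (9 carbon, 1 nitrogen, 2 oxygen; one five-membered non-aromatic ring with 1 hetero atom, one six-membered aromatic ring of carbon only), on an aromatic carbon. The change sits on an aromatic carbon of a five-membered aromatic ring with one nitrogen, part of a fused system of two rings, next to the ring atom that bears a chloro group and two ring bonds from the ring nitrogen.

Going by the values given here, no step between measured compounds that differ in one place is available to guide the expectation. The step from compound 1 to compound 3 is therefore expected to be small, a 1.2-fold higher number from compound 1 to compound 3 (0.06 log units; within the scatter), with no direction beyond the scatter. Compound 3 is estimated to give 40000 nM in this assay, with a range from 12000 nM to 130000 nM.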

Compound 3, concentration for total growth inhibition: 12600 nM
Estimate against measurement, compound 3: 3.2-fold (0.50 log units) above; low and high end bracket the measured number.
By their numbers in this assay, from the lowest: compound 3; then compounds 1 and 2 (each within the scatter of the next).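

In this assay, going by these compounds alone, the exchange on an aromatic carbon of a five-membered aromatic ring with 1 nitrogen gives a 2.8-fold lower number from compound 1 to compound 3 (0.44 log units; beyond the scatter) and is the first step that lies beyond the scatter, although it is modest in size. The earlier compounds differed in more than one place and offered no such reading, whereas here the two groups match in heavy-atom count and in their rings, so this position is shown to respond to a change in the content of the group alone. The entering group has 1 chlorine where the leaving group has a second oxygen, and it has 1 hydrogen-bond donor and 1 hydrogen-bond acceptor against 2 of each, but no measurement in hand bears on why the number falls.

The compounds shown do not separate the loss of the oxygen from the gain of the chlorine, so either could carry the step. They also leave open how a fluoro group, a methoxy group or an amine in the same group would compare, and whether the same exchange would move compound 2 by a similar amount.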